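Para-Substituted Benzyl Ether Variation at the Aryl Position

The source may report more compounds than this note shows. Statements on the series, on what has been measured and on what is new or still open speak of the compounds shown alone.

Compound 1 `COc1cccc(OC)c1OCCNCCOc1ccccc1OCc1cccc(C)c1` is the weaker of the two measured compounds in a functional assay on thoracic aorta for antagonist activity at Alpha-1D adrenergic receptor (Rattus norvegicus) (a lower number here means a less potent compound, a higher number a more potent compound, by a factor of ten per unit of this negative logarithm), where compound 1 gives 8.85. Compound 2 `COc1cccc(OC)c1OCCNCCOc1ccccc1OCc1ccc([N+](=O)[O-])cc1` gives 9.41, the step of a number 0.56 log units higher from compound 1 to compound 2 (beyond the scatter). Compound 3 `CCOc1ccc(COc2ccccc2OCCNCCOc2c(OC)cccc2OC)cc1` differs from compound 1 by 4-ethoxyphenyl in place of 3-methylphenyl on a saturated chain carbon bound to an oxygen on an aromatic ring. Among the compounds with values here, the only measured step at this place is that from compound 1 to compound 2, modest and upward; the change to compound 3 is not the same group, so a smaller upward step is expected, a number 0.25 log units higher from compound 1 to compound 3 (within the scatter). Compound 3 is therefore estimated at 9.1, with a range from 8.6 to 9.7.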

Compound 3, negative logarithm of the antagonist equilibrium constant: 9.11
For compound 3 the middle estimate is 0.01 log units below the measured one; the measured number falls inside the stated range.
By their numbers in this assay, from the lowest: compounds 1, 3 and 2 (each within the scatter of the next, the first and the last beyond it).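

In this assay, 4-ethoxyphenyl in place of 3-methylphenyl gives a number 0.26 log units higher from compound 1 to compound 3 (within the scatter), while ethoxy in place of nitro on an aromatic carbon gives a number 0.30 log units lower from compound 2 to compound 3 (within the scatter). Compound 3 therefore cannot be separated from either compound 1 or compound 2, although those two lie beyond the scatter of each other, so the numbers set no clear order for ethoxy at this place. Nothing available explains these steps. Going by these compounds, whether 4-aminophenyl or 4-carboxyphenyl on the same saturated chain carbon would remain within the scatter of compound 3 stays open, as does the effect of a butoxy chain in place of ethoxy.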